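The source may hold more compounds than are shown below. What is called first, only, known or untested is meant among the compounds shown, and "the series" means these compounds.

Of the compounds shown here, three built on one shared core have been tested in a functional assay on NCI-H23 cells (Homo sapiens) for cytotoxicity, read by sulforhodamine B assay, with a stated time of 72 h; on this read-out lower numbers stand for stronger inhibition of growth and higher numbers for weaker inhibition of growth. Compound 1 `O=C(Nc1ccccc1O)C1CCc2ccccc2N1C(=O)c1ccccc1Cl` gives 46900 nM. Compound 2 `CCCC(=O)N1c2ccccc2CCC1C(=O)Nc1ccccc1C(F)(F)F` returns only a limit of the assay, > 70000 nM, namely (the limit of > 70000 nM in this assay, at which 1 of the 3 values shown sits). Compound 3 `CCCCCCCCC(=O)N1c2ccccc2CCC1C(=O)Nc1ccccc1C(F)(F)F` gives 4220 nM, the lowest of the two numbers shown, with compound 1 the nearest measured value. Compound 4 `O=C(Nc1ccccc1C(F)(F)F)C1CCc2ccccc2N1` differs from compound 3 by hydrogen in place of octylcarbonyl on a nitrogen on an aromatic ring in a ring. Among the measured compounds shown here, the one measured step that bears on this chain, an at least 16-fold lower number from compound 2 to compound 3 (1.21 log units; beyond the scatter), was large and ran toward lower numbers as the chain grew; removing the whole octylcarbonyl in compound 4 is expected to run the other way, by a 14-fold higher number from compound 3 to compound 4 (1.15 log units; beyond the scatter). Compound 4 is therefore estimated at 60000 nM, between 15000 nM and 200000 nM, with a real chance that only a limit is reported.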

Compound 4, concentration for 50% growth inhibition: 56800 nM
For compound 4 the middle estimate is 1.1-fold (0.02 log units) above the measured one; measured number inside the range.
By their numbers in this assay, from the lowest: compound 3; then compounds 1 and 4 (each within the scatter of the next). At a limit, above all of these: compound 2.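

In this assay, hydrogen in place of octylcarbonyl on this nitrogen gives a 13-fold higher number from compound 3 to compound 4 (1.13 log units; beyond the scatter), so the low number of compound 3 depends on that acyl group and the bare core does not supply it. The shorter propylcarbonyl shows no such readable gain over hydrogen, the comparison being an at least 1.2-fold lower number from compound 2 to compound 4 (0.09 log units; that floor lies within the scatter). The value of compound 2 is a limit of the assay: the limit of > 70000 nM in this assay, at which 1 of the 4 values shown sits.

Where between propylcarbonyl and octylcarbonyl the number begins to fall remains open. So does whether a longer chain, or one ending in an amine or a carboxylic acid, would keep the gain.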